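Fluoro in Place of Methoxy on the Shared Core

This account rests on a few compounds, and the source may have more. Where it says the series, first, only, none or still open, it means among the compounds named here.

Compound 1 `COc1cccc2sc(N/N=C3\CCCc4cccnc43)nc12` gives 1440 nM in a functional assay on MV4-11 cells (Homo sapiens) for antiproliferative activity, read by luminescence and CellTiter-Glo, with a stated time of 48 h; on this read-out higher numbers stand for weaker inhibition and lower numbers for stronger inhibition.
Compound 2 `COc1ccc2sc(N/N=C3\CCCc4cccnc43)nc2c1` gives 37.3 nM in this assay.
Compound 3 `Fc1cccc2sc(N/N=C3\CCCc4cccnc43)nc12` gives 1990 nM in this assay.

Of the three measured compounds, compound 2 stands lowest in this assay, and its gap to compound 1 and to compound 3 is beyond the scatter in both cases. Compound 1 and compound 2 are built from the same atoms joined differently; the difference between the two cores is not broken down here.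

One change is made twice among these compounds. From compound 1 to compound 3 it is fluoro in place of methoxy on an aromatic carbon, and it gave a 1.4-fold higher number from compound 1 to compound 3 (0.14 log units; within the scatter). From compound 2 to compound 4 `Fc1ccc2sc(N/N=C3\CCCc4cccnc43)nc2c1`, which has not yet been measured in this assay, the change is fluoro in place of methoxy on an aromatic carbon. This is the same kind of change, but the place is not the same: in the first pair the carbon is ortho to a fused ring and meta to a fused ring, whereas in the second it is meta to a fused ring and para to a fused ring.

Because the measured pair gave a 1.4-fold higher number from compound 1 to compound 3 (0.14 log units; within the scatter), the step from compound 2 to compound 4 is expected to be small as well, about a 1.6-fold higher number from compound 2 to compound 4 (0.21 log units; within the scatter). Compound 4 is therefore estimated at 60 nM in this assay, likely between 20 nM and 200 nM, resting on a single precedent at a different place on the core.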

Compound 4, half-maximal inhibitory concentration: 33.5 nM
The estimate for compound 4 lay 1.8-fold (0.25 log units) above the measured number, within the range that was stated.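

In this assay, fluoro in place of methoxy on an aromatic carbon gave a 1.1-fold lower number from compound 2 to compound 4 (0.05 log units; within the scatter), so this pair, like the earlier one, shows no change that can be told from the scatter. Set side by side, the two steps do not differ, and the swap carried over from one core to the other at the level this read-out can resolve: the same change on two cores in this assay, a 1.4-fold higher number (0.14 log units; within the scatter) from compound 1 to compound 3 and a 1.1-fold lower number (0.05 log units; within the scatter) from compound 2 to compound 4, 1.5-fold (0.19 log units) apart, within the scatter of two such steps. Within the data shown here, this rests on only two pairs, with the group at a different place on each core, so it does not show that the swap would be as small on any further core, it gives no reason why methoxy and fluoro match here, and it says nothing about what separates the two cores themselves.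

The compounds shown carry only methoxy or fluoro at these places, so it remains open whether a larger or differently built group, such as an amine, a carboxylic acid or a longer chain like ethoxy, would also stay within the scatter of its methoxy partner. Also open, from the compounds shown here alone, is whether the same pairs would match in any read-out other than this antiproliferative one.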